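Amide to Urea on a Shared Pyrazole-Pyridine Scaffold

The source may hold more compounds than are shown below. What is called first, only, known or untested is meant among the compounds shown, and "the series" means these compounds.

Measured compounds and their values:
Compound 1 `O=C(Nc1cccc(-n2cc(-c3ccncc3)c(-c3ccc(Cl)c(O)c3)n2)c1)Nc1ccc(Cl)c(Cl)c1` in a functional assay on SNB-19 cells (Homo sapiens) for inhibition, read by sulforhodamine B assay, with a stated time of 48 h (a lower number here means a stronger inhibitor of growth, a higher number a weaker inhibitor of growth), gives > 32500 nM, a limit of the assay rather than a number.
Compound 2 `COc1cc(-c2nn(-c3cccc(NC(=O)c4ccc(Cl)c(C(F)(F)F)c4)c3)cc2-c2ccncc2)ccc1Cl` in this assay gives > 32500 nM, also a limit.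
Compound 3 `COc1cc(-c2nn(-c3cccc(NC(=O)c4cccc(C(F)(F)F)c4)c3)cc2-c2ccncc2)ccc1Cl` in this assay gives > 50000 nM, again a limit.

Compound 3 thus stands at a limit, not at a measured number. The other two values shown are limits as well (the limit of > 32500 nM in this assay, at which 2 of the 3 values shown sit, (the limit of > 50000 nM in this assay, at which 1 of the 3 values shown sits)). Compound 4 `COc1cc(-c2nn(-c3cccc(NC(=O)Nc4cccc(C(F)(F)F)c4)c3)cc2-c2ccncc2)ccc1Cl` differs from compound 3 by (3-(trifluoromethyl)phenyl)amino in place of 3-(trifluoromethyl)phenyl on a carbonyl carbon. Going by the values given here, the only measured step, a step that the two limits leave unreadable from compound 2 to compound 3, concerns another position and its size cannot be read. Compound 1 carries the same kind of linkage that enters here and is itself at a limit. No readable step therefore bears on this change, and no movement beyond the scatter is expected in this assay. Compound 4 is estimated at 50000 nM (range 20000 nM to 120000 nM), an expected step of a number no higher from compound 3 to compound 4 (the limit leaves the size open).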

Compound 4, concentration for total growth inhibition: 4000 nM
Beside the measured number, compound 4's estimate is 13-fold (1.10 log units) above it; the measured number lies below the stated range.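

In this assay, going by these compounds alone, (3-(trifluoromethyl)phenyl)amino in place of 3-(trifluoromethyl)phenyl on the carbonyl carbon gives an at least 12-fold lower number from compound 3 to compound 4 (1.09 log units; beyond the scatter), the only step here that ends on a measured number. Its replacing 4-chloro-3-(trifluoromethyl)phenyl gives an at least 8.1-fold lower number from compound 2 to compound 4 (0.90 log units; beyond the scatter). The urea linkage alone does not account for this, as compound 1, which differs from compound 4 elsewhere too, stays at a limit: the limit of > 32500 nM in this assay, at which 2 of the 4 values shown sit.

From the compounds shown here alone, the full size of the step stays open, as compound 3 is also at a limit: the limit of > 50000 nM in this assay, at which 1 of the 4 values shown sits. Whether the entering nitrogen's hydrogen matters stays open too, and a methyl group on that nitrogen, or a methylene group in its place, would separate the two.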